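Swapping Cyano for Methyl on a Selenium

This account rests on a few compounds, and the source may have more. Where it says the series, first, only, none or still open, it means among the compounds named here.

In a functional assay on RKO cells (Homo sapiens) for inhibition, read by MTT assay, with a stated time of 48 h (on this read-out lower numbers stand for stronger inhibition and higher numbers for weaker inhibition), compound 1 `Cc1nc(N(C)c2ccc([Se]C#N)c(C)c2)c2ccccc2n1` gives 17 nM and compound 2 `Cc1nc(N(C)c2ccc([Se]C#N)c(Cl)c2)c2ccccc2n1` gives 11 nM, values within the usual scatter of each other. Compound 3 `C[Se]c1ccc(N(C)c2nc(C)nc3ccccc23)cc1C` carries methyl in place of cyano on a selenium. For the measured compounds named here, the only measured step, a 1.5-fold lower number from compound 1 to compound 2 (0.19 log units; within the scatter), puts chloro in place of methyl on an aromatic carbon, elsewhere in the molecule. Going by the values given here, no measured step touches the selenium, so the size is uncertain, and no shift beyond the scatter is expected. The expected step is a 1.1-fold lower number from compound 1 to compound 3 (0.05 log units; within the scatter). In this assay, the estimate for compound 3 is 15 nM, within a range of 4 nM to 70 nM.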

Compound 3, half-maximal inhibitory concentration: 8 nM
Compound 3: middle estimate off by 1.9-fold (0.27 log units), on the high side, within the range that was stated.
By their numbers in this assay, from the lowest: compounds 3, 2 and 1 (each within the scatter of the next, the first and the last beyond it).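

Methyl in place of cyano on a selenium gives a 2.1-fold lower number from compound 1 to compound 3 (0.33 log units; beyond the scatter) in this assay and so shows that, in this pair, the cyano group is not required for strong inhibition. For the compounds shown here, this is the first measured change at the selenium, and the step is modest. Nothing measured here explains it. Going by these compounds, whether a longer chain such as ethyl on the selenium would give a lower or higher number remains open. So does whether sulfur in place of selenium would keep the inhibition seen with compound 3.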